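Swapping the trimethoxyphenyl group of compound 2

The compounds below may be only part of what the source reports. "The series", "measured", "known", "first", "only" and "open" are said of these compounds alone.

In a functional assay on A549 cells (Homo sapiens) for antiproliferative activity, read by sulforhodamine B assay, with a stated time of 48 h (a lower number here means a stronger inhibitor, a higher number a weaker inhibitor), compound 1 (`COc1ccc(OC)c(/C=C/C(=O)/C=C(O)/C=C/c2cc(OC)ccc2OC)c1`) gives 16300 nM and compound 2 (`COc1cccc(/C=C/C(=O)C(=Cc2cc(OC)c(OC)c(OC)c2)C(=O)/C=C/c2cccc(OC)c2OC)c1OC`) gives 230 nM as the lower of the two numbers, a gap beyond the scatter. Compound 3 (`COc1cc(C=C(C(=O)/C=C/c2cccc(OC)c2OC)C(=O)/C=C/c2cccc(OC)c2OC)cc(Br)c1O`) carries 3-bromo-4-hydroxy-5-methoxyphenyl in place of 3,4,5-trimethoxyphenyl on a double-bonded chain carbon bound to a double-bonded chain carbon. Among the compounds with values here, no measured pair shows this change, so the expectation is loose: a modest move to a higher number in this assay that lands not far past the scatter. The expected size is a 2.2-fold higher number from compound 2 to compound 3 (0.34 log units; beyond the scatter) on this estimate. Compound 3 is estimated at 500 nM with 150 nM to 1800 nM as the expected range.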

Compound 3, half-maximal inhibitory concentration: 200 nM
For compound 3 the middle estimate is 2.5-fold (0.40 log units) above the measured one, within the range that was stated.
By their numbers in this assay, from the lowest: compounds 3 and 2 (each within the scatter of the next); then compound 1.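

In this assay the place on a double-bonded chain carbon bound to a double-bonded chain carbon takes 3-bromo-4-hydroxy-5-methoxyphenyl in place of 3,4,5-trimethoxyphenyl with a 1.2-fold lower number from compound 2 to compound 3 (0.06 log units; within the scatter). This first single-place step in the series shows that this aryl swap, which brings in bromine and a hydrogen-bond donor, leaves the two numbers level within the scatter. No measurement at hand offers an explanation for this result.

Still open, going by these compounds, is how an amine or a carboxylic acid on this ring would read. Within the data shown here, the single swap also does not separate the share of the bromine from that of the hydroxyl.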